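The compounds below may be only part of what the source reports. "The series", "measured", "known", "first", "only" and "open" are said of these compounds alone.

Measured compounds:
Compound 1 `COc1cc(-c2cc(/C=C/C(=O)c3ccc(N)cc3)[nH]n2)cc(OC)c1OC`, giving 2210 nM in a functional assay on PC-3 cells (Homo sapiens) for inhibition, read by sulforhodamine B assay, with a stated time of 48 h; on this read-out lower numbers stand for stronger inhibition of growth and higher numbers for weaker inhibition of growth.
Compound 2 `COc1ccc(C(=O)/C=C/c2cc(-c3cc(OC)c(OC)c(OC)c3)n[nH]2)cc1`, giving 1510 nM in this assay.

Among the compounds with values here, compound 2 has the lowest of the two numbers measured so far; its nearest neighbour is compound 1, and the step of a 1.5-fold lower number from compound 1 to compound 2 (0.17 log units; within the scatter) is within the scatter, so the two compounds cannot be ranked against each other. Compound 3 `COc1cc(-c2cc(/C=C/C(=O)c3ccc(F)c(F)c3)[nH]n2)cc(OC)c1OC` has not yet been measured. It differs from compound 2 by 3,4-difluorophenyl in place of 4-methoxyphenyl on a carbonyl carbon. Within the data shown here, the only measured step that bears on this change is the one from compound 1 to compound 2, which also alters the substituent on the aryl ring attached to the carbonyl carbon, and that step was within the scatter. A change at the same place is therefore expected to give a step of similar size, that is none beyond the scatter, and the expected step of a 1.2-fold higher number from compound 2 to compound 3 (0.08 log units; within the scatter) reflects this. Compound 3 is therefore estimated at 1800 nM in this assay, with a range from 600 nM to 5500 nM.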

Compound 3, concentration for 50% growth inhibition: 1660 nM
Compound 3: middle estimate off by 1.1-fold (0.04 log units), on the high side, within the range that was stated.
By their numbers in this assay, from the lowest: compounds 2, 3 and 1 (each within the scatter of the next).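

On the carbonyl carbon, 3,4-difluorophenyl in place of 4-methoxyphenyl gives a 1.1-fold higher number from compound 2 to compound 3 (0.04 log units; within the scatter) in this assay, and 3,4-difluorophenyl in place of 4-aminophenyl gives a 1.3-fold lower number from compound 1 to compound 3 (0.12 log units; within the scatter) in the same test. The earlier pair varied only an amino or methoxy substituent, whereas this result adds an aryl group carrying fluorine and no hydrogen-bond acceptor, and compound 3 still cannot be told apart from compound 1 or compound 2. No measurement shown here explains why these three aryl groups read alike.

The compounds shown leave open whether any group on this carbonyl carbon can move the number beyond the scatter. A carboxylic acid on the phenyl ring, or a dimethylamino group there, would test this, as would a pyridine ring in place of the phenyl ring.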